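A few compounds are considered here, and "the series" means these few. Any claim that something is new, unique, unknown or untested is made for them only; others in the source may bear on it.

Series notes. Two members of the set have so far been run in a functional assay on EL4 cells (Mus musculus) for inhibition, tested at 100 uM; a higher number here means more inhibition at the concentration tested (going by the name of the read-out), a lower number less inhibition. Within the data shown here, compound 1, `OCCNc1[nH]ccc2ncnc1-2`, is the first of them. In this assay compound 1 gives < 5%, which is a limit of the assay and not a measured number. Compound 2, `CN(C)c1nccc2c1ncn2[C@H]1C[C@H](O)[C@@H](CO)O1`, is the second. In this assay compound 2 likewise returns only a limit, < 5%, rather than a number. Compound 2 thus stands at the limit of < 5% in this assay, at which 2 of the 2 values shown sit. Among the measured compounds shown here, neither measured compound rises off the floor of the read-out, and no measured pair of the set differs in a single place, so no step size is known from measurement.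

Compound 3, `OC[C@H]1O[C@@H](n2cnc3c(SCc4ccccc4)nccc32)C[C@@H]1O`, has not yet been measured in this assay. It differs from compound 2 as follows: benzylsulfanyl in place of dimethylamino on an aromatic carbon.

For the measured compounds named here, with no measured step to lean on, the move from compound 2 to compound 3 in this assay is expected to be a number at least 7 percentage points higher from compound 2 to compound 3 (that floor lies within the scatter), a small rise that may not clear the scatter. Compound 3 is accordingly estimated to give 12% in this assay, within a range of 0% to 40%.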

Compound 3, a percentage reported as inhibition, at one concentration (the size of the read-out at that concentration, not a potency): 11%
Beside the measured number, compound 3's estimate is 1 percentage points above it; the measured number falls inside the stated range.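

In this assay, among these compounds, the exchange of dimethylamino for benzylsulfanyl on the aromatic carbon next to the ring nitrogen gives the first reading of a change at this position, a number at least 6 percentage points higher from compound 2 to compound 3 (that floor lies within the scatter). Among the compounds shown here, compound 3, at 11%, is also the first member of the set with a measured number instead of a limit, so this position accepts a benzylsulfanyl group, with its six-membered aromatic ring of carbon only, and the read-out in this assay remains a number, though a small one. The true size of the step remains uncertain because compound 2 has only a limit, not a number: the limit of < 5% in this assay, at which 2 of the 3 values shown sit.

As far as these compounds go, it remains open whether the sulfur link, the benzyl ring or neither accounts for any of this step, and a benzylamino or methylsulfanyl group on the same carbon would help to separate those parts. Also open, from the compounds shown here alone, is whether a longer alkyl chain or a substituted benzyl group at this position could raise inhibition in this assay clearly beyond the usual scatter of repeated measurements.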